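A few compounds are considered here, and "the series" means these few. Any claim that something is new, unique, unknown or untested is made for them only; others in the source may bear on it.

Measured compounds in a functional assay on SGC-7901 cells (Homo sapiens) for antiproliferative activity, read by MTT assay, with a stated time of 72 h; on this read-out lower numbers stand for stronger inhibition and higher numbers for weaker inhibition:
- compound 1 `COc1cc(-n2cnc3ccc(-c4ccc(C(C)=O)cc4)cc32)cc(OC)c1OC` gives 450 nM
- compound 2 `COc1cc(-n2cnc3ccc(-c4cccc(Cl)c4)cc32)cc(OC)c1OC` gives 1490 nM
- compound 3 `COc1cc(-n2cnc3ccc(-c4cccc(F)c4)cc32)cc(OC)c1OC` gives 2490 nM

Compound 1 holds the lowest number of the three. Its nearest neighbour is compound 2, reached by a 3.3-fold higher number from compound 1 to compound 2 (0.52 log units; beyond the scatter), and the furthest is compound 3, reached by a 5.5-fold higher number from compound 1 to compound 3 (0.74 log units; beyond the scatter); both steps lie beyond the scatter. Between the two halogen analogues the step of a 1.7-fold higher number from compound 2 to compound 3 (0.22 log units; within the scatter) lies within the scatter, so compounds 2 and 3 are not separated on this read-out.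

Compound 4 `COc1cc(-n2cnc3ccc(-c4cccc(C)c4C)cc32)cc(OC)c1OC` differs from compound 1 at one place: 2,3-dimethylphenyl in place of 4-acetylphenyl on an aromatic carbon. Going by the values given here, no measured pair covers exactly this exchange. The two steps that bear on it are the ones leaving compound 1, in which the 4-acetylphenyl is replaced by 3-chlorophenyl or 3-fluorophenyl; each raised the number by a modest amount and beyond the scatter. The 2,3-dimethylphenyl likewise carries no hydrogen-bond acceptor where the 4-acetylphenyl carries one. A rise of similar size is therefore expected, and in this assay the step of a 3.3-fold higher number from compound 1 to compound 4 (0.52 log units; beyond the scatter) is the working estimate. Compound 4 is expected to give 1500 nM, with a range from 600 nM to 4000 nM.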

Compound 4, half-maximal inhibitory concentration: 3040 nM
Estimate against measurement, compound 4: 2.0-fold (0.31 log units) below; low and high end bracket the measured number.
By their numbers in this assay, from the lowest: compound 1; then compounds 2, 3 and 4 (each within the scatter of the next, the first and the last beyond it).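

In this assay, a third replacement of the 4-acetylphenyl, this time one without halogen, also gives a higher number: a 6.8-fold higher number from compound 1 to compound 4 (0.83 log units; beyond the scatter). Compound 1 therefore stays alone at the low end against 3-chlorophenyl, 3-fluorophenyl and 2,3-dimethylphenyl on this aromatic carbon, and the two methyl groups do not recover what is lost on leaving the 4-acetylphenyl. Among the three replacements the picture is not a clean order: a 1.2-fold higher number from compound 3 to compound 4 (0.09 log units; within the scatter) does not separate the 2,3-dimethylphenyl from the 3-fluorophenyl, whereas a 2.0-fold higher number from compound 2 to compound 4 (0.31 log units; beyond the scatter) does set it apart from the 3-chlorophenyl, and nothing available accounts for any of these differences.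

The 4-acetylphenyl differs from the other three groups both in carrying a carbonyl and in where its substituent sits, so the compounds shown cannot tell these two features apart; a 3-acetylphenyl or a 4-chlorophenyl at this place would separate them. On these data alone, how a phenyl ring bearing an amine or a carboxylic acid would read at this carbon also remains open.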